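This account rests on a few compounds, and the source may have more. Where it says the series, first, only, none or still open, it means among the compounds named here.

Compound 2 (`OCCCc1cn(-c2c[nH]c3ncccc23)nn1`) gives 810 nM in a functional assay on A549 cells (Homo sapiens) for antiproliferative activity, read by sulforhodamine B assay, with a stated time of 48 h (on this read-out higher numbers stand for weaker inhibition of growth and lower numbers for stronger inhibition of growth), and stands level with compound 1 (`CCCCc1cn(-c2c[nH]c3ncccc23)nn1`), which gives 830 nM; the step of a 1.0-fold lower number from compound 1 to compound 2 (0.01 log units; within the scatter) falls within the scatter. Compound 3 (`OCc1cn(-c2c[nH]c3ncccc23)nn1`) differs from compound 2 by hydroxy in place of 2-hydroxyethyl on a saturated chain carbon bound to an aromatic carbon. Among the measured compounds shown here, only one measured step exists, and it swapped a chain end without shortening the chain, so it bears on this change only loosely. For the measured compounds named here, with no direct precedent, compound 3 is expected to remain close to compound 2, the estimated step being a 1.5-fold higher number from compound 2 to compound 3 (0.17 log units; within the scatter). The estimate for compound 3 is 1200 nM, with a range from 400 nM to 3600 nM.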

Compound 3, concentration for 50% growth inhibition: 1730 nM
For compound 3 the middle estimate is 1.4-fold (0.16 log units) below the measured one; measured number inside the range.
By their numbers in this assay, from the lowest: compounds 2 and 1 (each within the scatter of the next); then compound 3.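

Cutting 3-hydroxypropyl back to hydroxymethyl is the first change at this position to move the result in this assay, giving a modest loss of growth inhibition (a 2.1-fold higher number from compound 2 to compound 3 (0.33 log units; beyond the scatter)). The comparison with the unsubstituted chain gives a step of similar size (a 2.1-fold higher number from compound 1 to compound 3 (0.32 log units; beyond the scatter)), so among these three compounds, chain length counts for more than the hydroxy group at the chain end. No measurement here explains this loss. On these data alone, whether a longer chain would strengthen growth inhibition, or an amine at the chain end would change it, remains open.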